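A few compounds are considered here, and "the series" means these few. Any claim that something is new, unique, unknown or untested is made for them only; others in the source may bear on it.

Three compounds share the core of compound 1 `O=C1/C(=C/c2ccccc2Cl)Cc2ccccc21` and differ only in the group on the pendant aromatic ring. In a functional assay on CCRF-CEM cells (Homo sapiens) for inhibition (on this read-out lower numbers stand for stronger inhibition and higher numbers for weaker inhibition), compound 1 gives 57000 nM, compound 2 `O=C1/C(=C/c2ccccc2F)Cc2ccccc21` gives 47100 nM and compound 3 `O=C1/C(=C/c2ccccc2[N+](=O)[O-])Cc2ccccc21` gives 3530 nM. Compound 3 has the lowest number of the three, with steps of a 16-fold lower number from compound 1 to compound 3 (1.21 log units; beyond the scatter) and a 13-fold lower number from compound 2 to compound 3 (1.13 log units; beyond the scatter), whereas a 1.2-fold lower number from compound 1 to compound 2 (0.08 log units; within the scatter). Compound 4 `Cc1ccccc1/C=C1\Cc2ccccc2C1=O` is made from compound 3 by the change (methyl in place of nitro on an aromatic carbon). The two large steps that brought in the nitro group bear on this: both the chloro and the fluoro compounds sat far above compound 3. Replacing nitro by another small group is therefore expected to produce a step of an 11-fold higher number from compound 3 to compound 4 (1.05 log units; beyond the scatter). Compound 4 is expected to give 40000 nM, within the range 10000 nM to 120000 nM.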

Compound 4, half-maximal inhibitory concentration: 56500 nM
Estimate against measurement, compound 4: 1.4-fold (0.15 log units) below; low and high end bracket the measured number.
By their numbers in this assay, from the lowest: compound 3; then compounds 2, 4 and 1 (each within the scatter of the next).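

Methyl in place of nitro on this aromatic carbon undoes the gain seen with nitro (a 16-fold higher number from compound 3 to compound 4 (1.20 log units; beyond the scatter)), so the low number of compound 3 is not something any group other than chloro or fluoro brings. Compound 4 falls level with both halogen compounds (a 1.2-fold higher number from compound 2 to compound 4 (0.08 log units; within the scatter); a 1.0-fold lower number from compound 1 to compound 4 (0.00 log units; within the scatter)), leaving nitro alone apart among the four groups. Nothing available explains why nitro stands apart.

From the compounds shown here alone, whether an amine, a nitrile or a carboxylic acid here would match compound 3 stays open. So does whether nitro elsewhere on the ring would.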